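The compounds below may be only part of what the source reports. "The series", "measured", "known", "first", "only" and "open" are said of these compounds alone.

Measured so far:
Compound 1 `COc1cc(-c2ncnn2-c2ccc([N+](=O)[O-])cc2)cc(OC)c1OC`: > 10000 nM
Compound 2 `COc1cc(-n2ncnc2-c2ccc(OC(F)(F)F)cc2)cc(OC)c1OC`: > 10000 nM

In a functional assay on HeLa cells (Homo sapiens) for antiproliferative activity, read by MTT assay, with a stated time of 72 h (a lower number here means a stronger inhibitor, a higher number a weaker inhibitor), compound 2 stands at > 10000 nM and this is a limit of the assay, not a number. Compound 1 gives > 10000 nM and this too is a limit. Within the data shown here, the series so far offers only the limit of > 10000 nM in this assay, at which 2 of the 2 values shown sit, and no graded value.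

Compound 3 `COc1cc(-n2ncnc2-c2ccc(SC)cc2)cc(OC)c1OC` carries methylsulfanyl in place of trifluoromethoxy on an aromatic carbon, para to a large group: methylsulfanyl in place of trifluoromethoxy on an aromatic carbon.

No measured step sizes this change. The expected direction rests on compound 2 at > 10000 nM as a limit, so any measurable value could only lie on the stronger side. In this assay the expected step of an at least 3.3-fold lower number from compound 2 to compound 3 (0.52 log units; beyond the scatter) is therefore an uncertain estimate, and another limit remains quite possible. For compound 3 the estimated value is 3000 nM with an expected range from 100 nM to 15000 nM in this read-out.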

Compound 3, half-maximal inhibitory concentration: 150 nM
Estimate against measurement, compound 3: 20-fold (1.30 log units) above; low and high end bracket the measured number.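

In this assay, the substituent on the aromatic carbon para to a large group clearly matters: methylsulfanyl in place of trifluoromethoxy gives an at least 66-fold lower number from compound 2 to compound 3 (1.82 log units; beyond the scatter). Compound 2 stands at > 10000 nM, a limit of the assay and not a number. Compound 3 therefore gives the series its first graded value, set against the rest of what is shown: the limit of > 10000 nM in this assay, at which 2 of the 3 values shown sit.

As far as these compounds go, whether methoxy, ethylsulfanyl or methylsulfonyl at this place would also give a graded value stays open, and a single pair cannot show whether the sulfur atom or some other difference between the two groups accounts for the step. Among these compounds, compound 1 differs from compound 3 in more than one place, so no step between them can be read.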